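Moving the chlorine on the phenoxy tail: compound 3 to compound 4

A few compounds are considered here, and "the series" means these few. Any claim that something is new, unique, unknown or untested is made for them only; others in the source may bear on it.

Among the compounds with values here, compound 1 `NC1=NC2(CCSCC2)N(OCCCOc2ccc(Cl)c(Cl)c2)C(N)=N1` is the only member of this set with a number in an assay on isolated protein for inhibition of Dihydrofolate reductase (Homo sapiens), read by spectrophotometry, using NADPH, with stated times of 5 s and 6 min, tested at 50 uM; a lower number here means a weaker effect, a higher number a stronger effect of the compound at the concentration tested; compound 1 gives 89.8%. Compound 2 `NC1=NC2(CCOCC2)N(OCCCOc2ccccc2)C(N)=N1` has no result in this assay, where compound 2 gives "not determined" (no result reported). Compound 3 `NC1=NC2(CCOCC2)N(OCCCOc2ccc(Cl)cc2)C(N)=N1` likewise stands without a single number in this assay, where compound 3 gives "not determined" (no result reported); one further member of the series shares this lack. Compound 4 `NC1=NC2(CCOCC2)N(OCCCOc2ccccc2Cl)C(N)=N1` is not yet measured in this assay. The change from compound 3 to compound 4 is 2-chlorophenyl in place of 4-chlorophenyl on an oxygen on a saturated carbon. Within the data shown here, no measured step covers this change, and with compound 3 unquantified no step can be stated for it; in this assay no step beyond the scatter is expected from this change in either direction, though the data cannot confirm this. Compound 4 is expected to show 70% in this assay, with a range from 35% to 95%. This expectation rests only on compound 1, which gives 89.8%.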

Compound 4, a percentage reported as inhibition, at one concentration (the size of the read-out at that concentration, not a potency): 88.2%
For compound 4 the middle estimate is 18.2 percentage points below the measured one; low and high end bracket the measured number.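

No step can be read from compound 3 to compound 4 in this assay: compound 3 has no single number there, while compound 4 gives 88.2%. The compounds shown leave open what 2-chlorophenyl in place of 4-chlorophenyl does to this read-out, and no supporting evidence bears on the result.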